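The compounds below may be only part of what the source reports. "The series", "measured", "known", "first", "only" and "open" are said of these compounds alone.

The measured compounds are:
compound 1, `Cc1nc2c3ccccc3ccc2c2nc3c(ccc4ccccc43)c(-c3ccccc3S)c12`, 4070 nM
compound 2, `Cc1nc2c3ccccc3ccc2c2nc3c(ccc4ccccc43)c(-c3cc([N+](=O)[O-])ccc3N)c12`, 17800 nM
compound 3, `Cc1nc2c3ccccc3ccc2c2nc3c(ccc4ccccc43)c(-c3cccc([N+](=O)[O-])c3)c12`, 25500 nM

All three share one core and differ only in the ring that hangs from it. In a functional assay on AGS cells (Homo sapiens) for cytotoxicity, read by MTT assay, with a stated time of 48 h (on this read-out higher numbers stand for weaker inhibition and lower numbers for stronger inhibition), compound 3 gives the highest of the three numbers, which here means the weakest inhibition. Its gap to compound 2 is small: a 1.4-fold higher number from compound 2 to compound 3 (0.16 log units; within the scatter). Its gap to compound 1 is larger: a 6.3-fold higher number from compound 1 to compound 3 (0.80 log units; beyond the scatter). Compound 1 to compound 2 also moved by a modest amount: a 4.4-fold higher number from compound 1 to compound 2 (0.64 log units; beyond the scatter).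

Compound 4, `Cc1nc2c3ccccc3ccc2c2nc3c(ccc4ccccc43)c(-c3ccc(O)cc3)c12`, has not been measured. It differs from compound 3 in one place: 4-hydroxyphenyl in place of 3-nitrophenyl on an aromatic carbon. Among the measured compounds shown here, the three measured steps all alter this same pendant ring, so they bear directly on the question, but none of them brings in a hydroxyl group, and the only steps beyond the scatter ran from the lowest number upward. What can be read from the data is that swapping this ring has shifted the number by modest amounts at most. Compound 4 is therefore estimated to come out somewhat lower than compound 3, a 2.1-fold lower number from compound 3 to compound 4 (0.33 log units; beyond the scatter), with the direction uncertain. Compound 4 is expected to give 12000 nM, within a range from 4000 nM to 36000 nM.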

Compound 4, half-maximal inhibitory concentration: 14200 nM
Estimate against measurement, compound 4: 1.2-fold (0.07 log units) below; measured number inside the range.
By their numbers in this assay, from the lowest: compound 1; then compounds 4, 2 and 3 (each within the scatter of the next).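

In this assay, the 4-hydroxyphenyl ring of compound 4 cannot be told apart from either nitro-bearing ring, with a 1.8-fold lower number from compound 3 to compound 4 (0.25 log units; within the scatter) against the 3-nitrophenyl ring and a 1.3-fold lower number from compound 2 to compound 4 (0.10 log units; within the scatter) against the 2-amino-5-nitrophenyl ring, so at this position a nitro group is not needed to reach this level of activity. The 2-sulfanylphenyl ring remains the one clear outlier, with a 3.5-fold higher number from compound 1 to compound 4 (0.54 log units; beyond the scatter) on replacing it by 4-hydroxyphenyl, which leaves compound 1 the strongest of the four and places the other three rings in a single group despite their different substituents. No measured evidence here explains why these rings group as they do.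

From the compounds shown here alone, whether the lower number of compound 1 comes from the sulfanyl group itself or from where it sits on the ring remains open, since the other three rings carry different groups in different places. Also open, going by these compounds, is how this position would respond to a plain phenyl ring, a methoxy group or a carboxylic acid, any of which would show how far the flat level seen with compounds 2, 3 and 4 extends.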